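Fluoro for chloro on the shared core

The source may report more compounds than this note shows. Statements on the series, on what has been measured and on what is new or still open speak of the compounds shown alone.

Measured compounds in an ADME assay on microsomes from liver (Rattus norvegicus) for metabolic stability, read by LC-MS, using NADPH, with a stated time of 30 min, tested at 1 uM (a higher number here means that more of the compound is left, a lower number that less of the compound is left), are these
- compound 1 `C=CC(=O)Nc1cc(Nc2ncc(I)c(Nc3ccccc3S(=O)(=O)N(C)C)n2)c(OC)cc1N(C)CCN(C)C` gives 12% of parent left
- compound 2 `C=CC(=O)Nc1cc(Nc2ncc(F)c(Nc3ccccc3S(=O)(=O)N(C)C)n2)c(OC)cc1N(C)CCN(C)C` gives 7% of parent left
- compound 3 `C=CC(=O)Nc1cc(Nc2ncc(Cl)c(Nc3ccccc3S(=O)(=O)C(C)C)n2)c(OC)cc1N(C)CCN(C)C` gives 11% of parent left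

Compound 3 at 11% sits within the scatter of both compound 1 and compound 2, so the three values cannot be ranked.

Compound 4 `C=CC(=O)Nc1cc(Nc2ncc(F)c(Nc3ccccc3S(=O)(=O)C(C)C)n2)c(OC)cc1N(C)CCN(C)C` is not yet measured. Its difference from compound 3 is fluoro in place of chloro on an aromatic carbon and amounts to fluoro in place of chloro on an aromatic carbon, ortho to a large group, two atoms from the ring nitrogen and para to a large group.

Within the data shown here, the one measured step of this kind is a number 5 percentage points lower from compound 1 to compound 2 (within the scatter) with fluoro in place of iodo on an aromatic carbon. That step stays within the scatter. Among the measured compounds shown here, no direct step from chloro to fluoro has been measured, and compound 1 and compound 2 also differ from compound 3 elsewhere in the structure. For the measured compounds named here, compound 2 at 7% is the only measured fluoro compound.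

No step beyond the scatter is therefore expected in this assay for this change. The expected size is a number 3 percentage points lower from compound 3 to compound 4 (within the scatter) and this estimate stays within the scatter. For compound 4 the expected value is 8% with an estimated range from 3% to 15% as the working figure.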

Compound 4, percent of the compound remaining: 11%
Estimate against measurement, compound 4: 3 percentage points below; the measured number falls inside the stated range.
By their numbers in this assay, from the lowest: compounds 2, 3, 4 and 1 (each within the scatter of the next).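

In this assay, among these compounds, the only direct reading of this change on the shared core gives no change at the digits printed from compound 3 to compound 4 (within the scatter), so fluoro in place of chloro on this aromatic carbon, ortho to a large group, two atoms from the ring nitrogen and para to a large group, shows no step beyond the scatter with isopropyl on the sulfonyl sulfur. With fluoro held constant, the sulfonyl substituent can now also be read on its own, giving a number 4 percentage points higher from compound 2 to compound 4 (within the scatter), so isopropyl in place of dimethylamino on a sulfonyl sulfur likewise stays within the scatter. Nothing available bears on the reason for either result.

Whether the chloro-to-fluoro result holds with dimethylamino on the sulfonyl sulfur, and whether a nitrile or a methyl on this same aromatic carbon would also stay within the scatter of these compounds, remains open. Also open, from the compounds shown here alone, is whether a morpholine in place of the dimethylaminoethyl chain would move the percentage of compound remaining by more than the scatter.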